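Swapping a Hydroxyphenyl for a Fluorophenyl

The compounds below may be only part of what the source reports. "The series", "measured", "known", "first", "only" and "open" are said of these compounds alone.

Compound 1 `COc1ccc(S(=O)(=O)N2CCc3cccc(-c4ccc(O)cc4)c32)cc1` gives 129 nM in a functional assay on KB cells (Homo sapiens) for inhibition, with a stated time of 72 h (a higher number here means a weaker inhibitor, a lower number a stronger inhibitor), the lowest of the two numbers recorded so far. Compound 2 `COc1ccc(S(=O)(=O)N2CCc3cccc(-c4c(F)c(F)c(F)c(F)c4F)c32)cc1` gives 4040 nM in this assay, a far higher number that lies beyond the scatter. Compound 3 `COc1ccc(S(=O)(=O)N2CCc3cccc(-c4cccc(F)c4)c32)cc1` has not been measured; it differs from compound 1 by 3-fluorophenyl in place of 4-hydroxyphenyl on an aromatic carbon. Among the measured compounds shown here, no measured pair shares this change, so the expected step of a 3.9-fold higher number from compound 1 to compound 3 (0.59 log units; beyond the scatter) in this assay is estimated as a moderate move toward a weaker inhibitor, somewhat beyond the scatter. Compound 3 is expected to give about 500 nM, within 150 nM to 2000 nM.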

Compound 3, half-maximal inhibitory concentration: 98.5 nM
For compound 3 the middle estimate is 5.1-fold (0.71 log units) above the measured one; the whole stated range lies above it.
By their numbers in this assay, from the lowest: compounds 3 and 1 (each within the scatter of the next); then compound 2.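

In this assay, replacing 4-hydroxyphenyl with 3-fluorophenyl gives a 1.3-fold lower number from compound 1 to compound 3 (0.12 log units; within the scatter), so this position holds its level without the hydrogen-bond donor and acceptor of the leaving group. Compound 2, the pentafluorophenyl member, stands at 4040 nM, so a fluorinated phenyl here does not by itself secure that level. Nothing shown explains why the swap is tolerated. Still open, from the compounds shown here alone, is whether a phenyl bearing an amine, a carboxylic acid or a methoxy group would stay at this level, and how 4-fluorophenyl compares with 3-fluorophenyl.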